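This account rests on a few compounds, and the source may have more. Where it says the series, first, only, none or still open, it means among the compounds named here.

Two compounds of the series carry numbers in a functional assay on the whole organism (strain albino) for inhibition, with Rattus norvegicus as the target, read by paw edema, with stated times of 30 min and 1 h, at a dose of 5 mg/kg by the oral route; a higher number here means more inhibition at the dose given (going by the name of the read-out), a lower number less inhibition. Compound 1, `CCOC(=O)Cc1n[nH]c(NC(=O)c2ccc(Br)cc2)n1`, gives 31.3%. Compound 2, `CCOC(=O)Cc1n[nH]c(NC(=O)c2ccc(OC)cc2)n1`, gives 30.2%. Within the data shown here, the single step between them, a number 1.1 percentage points lower from compound 1 to compound 2 (within the scatter), shows that exchanging one group on the aromatic carbon for another left the read-out essentially where it was. Compound 2 stands at the lower of the two numbers, with compound 1 its nearest neighbour and within the scatter of it, so no order between the two can be drawn.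

Compound 3, `CCOC(=O)Cc1n[nH]c(NC(=O)c2ccc([N+](=O)[O-])cc2)n1`, is not yet measured. It differs from compound 2 thus: nitro in place of methoxy on an aromatic carbon. Among the measured compounds shown here, the one step that bears on this change, bromo to methoxy, is also an exchange of the group on the aromatic carbon, and it was within the scatter; on that basis no step beyond the scatter is expected, a number 0.2 percentage points lower from compound 2 to compound 3 (within the scatter). Compound 3 is therefore estimated at 30%, between 18% and 42%.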

Compound 3, a percentage reported as inhibition, in the whole organism at one dose (the size of the read-out at that dose, not a potency): 32.6%
The estimate for compound 3 lay 2.6 percentage points below the measured number; measured number inside the range.
By their numbers in this assay, from the lowest: compounds 2, 1 and 3 (each within the scatter of the next).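

In this assay, nitro in place of methoxy gives a number 2.4 percentage points higher from compound 2 to compound 3 (within the scatter), and nitro in place of bromo gives a number 1.3 percentage points higher from compound 1 to compound 3 (within the scatter). The position para to a large group thus now carries three different groups with no step beyond the scatter, including the exchange of methoxy for nitro, which brings more heavy atoms and hydrogen-bond acceptors and a double bond outside aromatic rings. Nothing at hand accounts for this flat reading.

As far as these compounds go, whether the read-out stays flat at this position with an amine, a carboxylic acid or a plain hydrogen remains open. Also open, from the compounds shown here alone, are whether a longer chain in place of the ethyl ester would move the number, and whether these three compounds would separate at another dose.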